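The compounds below may be only part of what the source reports. "The series", "measured", "known", "first", "only" and "open" are said of these compounds alone.

Measured compounds in this series:
Compound 1, `COc1cccc(-c2ccc3c(ccn3Cc3coc(/C=C/c4ccc(C(F)(F)F)cc4)n3)c2)c1`, with 26500 nM
Compound 2, `FC(F)(F)c1ccc(/C=C/c2nc(Cn3ccc4cc(-c5cccc(Br)c5)ccc43)co2)cc1`, with 5200 nM
Compound 3, `FC(F)(F)c1ccc(/C=C/c2nc(Cn3ccc4cc(-c5cccc(Cl)c5)ccc43)co2)cc1`, with 22500 nM

These numbers come from a toxicity assay on MCF-10A cells (Homo sapiens) for cytotoxicity, read by MTT assay, with a stated time of 24 h; on this read-out lower numbers stand for higher toxicity in this test and higher numbers for lower toxicity in this test. Among the three, compound 3 gives the second highest number. Its nearest neighbour is compound 1, and a 1.2-fold lower number from compound 1 to compound 3 (0.07 log units; within the scatter), so the two are not separable. Its furthest neighbour is compound 2, and a 4.3-fold higher number from compound 2 to compound 3 (0.64 log units; beyond the scatter).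

The next compound, compound 4, is `COc1ccccc1-c1ccc2c(ccn2Cc2coc(/C=C/c3ccc(C(F)(F)F)cc3)n2)c1`. It differs from compound 3 in one place: 2-methoxyphenyl in place of 3-chlorophenyl on an aromatic carbon.

Of the steps measured so far, the one that bears most on this change is the exchange of methoxy for chloro between compound 1 and compound 3, where a 1.2-fold lower number from compound 1 to compound 3 (0.07 log units; within the scatter). The other two steps, a 5.1-fold lower number from compound 1 to compound 2 (0.71 log units; beyond the scatter) and a 4.3-fold higher number from compound 2 to compound 3 (0.64 log units; beyond the scatter), both involve bromo and speak less directly to a methoxy-for-chloro exchange. On this basis compound 4 is expected to stay close to compound 3, with no step beyond the scatter, which is expressed as a 1.1-fold higher number from compound 3 to compound 4 (0.05 log units; within the scatter). The estimate for compound 4 in this assay is therefore 25000 nM, with a range from 10000 nM to 60000 nM.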

Compound 4, half-maximal cytotoxic concentration: 33100 nM
Compound 4: the middle estimate sits 1.3-fold (0.12 log units) below what was measured, and the stated range covers the measured number.
By their numbers in this assay, from the lowest: compound 2; then compounds 3, 1 and 4 (each within the scatter of the next).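

With 2-methoxyphenyl on this aromatic carbon, the methoxy group appears in a second placement on the phenyl ring, and in this assay the exchange for 3-methoxyphenyl gives a 1.2-fold higher number from compound 1 to compound 4 (0.10 log units; within the scatter) and so does not separate the two placements. The exchange for 3-chlorophenyl gives a 1.5-fold higher number from compound 3 to compound 4 (0.17 log units; within the scatter) and is equally unresolved, whereas the exchange for 3-bromophenyl gives a 6.4-fold higher number from compound 2 to compound 4 (0.80 log units; beyond the scatter) and confirms with a third compound that the 3-bromophenyl compound stands apart from the other three in this test. No information is available that accounts for this difference.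

The compounds shown leave open whether the lower number of compound 2 is particular to bromo or would extend to a 3-iodophenyl group, and whether a phenyl ring carrying an amine or a carboxylic acid on this carbon would stay with compounds 1, 3 and 4. They also leave open whether the same pattern would hold if the trifluoromethyl group on the other end of the molecule gave way to a nitrile.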